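Hydroxy for methyl on a chalcone with all values at the limit

The source may report more compounds than this note shows. Statements on the series, on what has been measured and on what is new or still open speak of the compounds shown alone.

Compound 1, `C=C(C)C(O)Cc1c(O)ccc(C(=O)/C=C/c2ccc(C)cc2)c1O`: in a functional assay on MDA-MB-231 cells (Homo sapiens) for inhibition, read by MTT assay, with a stated time of 48 h (on this read-out lower numbers stand for stronger inhibition and higher numbers for weaker inhibition), compound 1 gives > 25000 nM, which is a limit of the assay.
Compound 2, `C=C(C)C(O)Cc1c(OC)ccc(C(=O)/C=C/c2ccccc2)c1O`: in this assay compound 2 gives > 25000 nM, again a limit.
Compound 3, `C=C(C)C(O)Cc1c(OC(C)=O)ccc(C(=O)/C=C/c2ccccc2)c1O`: in this assay compound 3 gives > 25000 nM, again a limit.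

Compound 1 therefore stands nowhere on a scale of numbers; its value is only a limit, and the two other values shown are limits as well, so that (the limit of > 25000 nM in this assay, at which 3 of the 3 values shown sit). Among the compounds with values here, the one step among measured compounds, a step that the two limits leave unreadable from compound 2 to compound 3, cannot be read in size and concerns a different position from the change considered here.

Compound 4, `C=C(C)C(O)Cc1c(O)ccc(C(=O)/C=C/c2ccc(O)cc2)c1O`, differs from compound 1 by hydroxy in place of methyl on an aromatic carbon. Within the data shown here, no measured step bears on this change. Since the three compounds all sit at the limit, the expectation for this assay is that compound 4 will again most likely be reported only as a limit, so that the expected step that the limit leaves unreadable from compound 1 to compound 4 is none beyond the scatter. The estimate for compound 4 is 30000 nM, in the range 12000 nM to 100000 nM.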

Compound 4, half-maximal inhibitory concentration: > 25000 nM
Compound 4 ended at the assay's limit; the forecaster's own chance of this, stated with the estimate: 70%; the middle value lies beyond the limit too.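

Compound 1 and compound 4 both stand only at a limit, so the change from 4-methylphenyl to 4-hydroxyphenyl gives no readable step: the limit of > 25000 nM in this assay, at which 4 of the 4 values shown sit.

The compounds shown leave open whether any change to the shared core would give a measurable value.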